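Difluorophenyl Replacing Methylphenyl on the Aryl Ether

A few compounds are considered here, and "the series" means these few. Any claim that something is new, unique, unknown or untested is made for them only; others in the source may bear on it.

Compound 1, `Cc1nnsc1CO/N=C/c1c(C)nn(C)c1Oc1ccc(F)cc1`: in a functional assay on SGC-7901 cells (Homo sapiens) for inhibition, read by MTT assay, with a stated time of 48 h (a lower number here means a stronger inhibitor, a higher number a weaker inhibitor), compound 1 reaches only the limit of > 50000 nM.
Compound 2, `Cc1ccc(Oc2c(/C=N/OCc3snnc3C)c(C)nn2C)cc1`: in this assay compound 2 gives 12800 nM.

Going by the values given here, compound 2 holds the only actual number among the two results; the result for compound 1 is a limit and not a number, as stated by the limit of > 50000 nM in this assay, at which 1 of the 2 values shown sits. The step from compound 3, `Cc1nnsc1CO/N=C/c1c(C)nn(C)c1Oc1cccc(F)c1F`, back to compound 2 is 2,3-difluorophenyl in place of 4-methylphenyl on an oxygen on an aromatic ring. Among the compounds with values here, the one measured step that bears on this change is an at least 3.9-fold lower number from compound 1 to compound 2 (0.59 log units; beyond the scatter), where a single fluoro gave way to methyl and the number fell. Compound 3 moves the other way, from methyl to fluoro, and adds a second fluorine, so a step upward, that is toward a weaker inhibitor, is expected; its size cannot be read closely from a step that is itself only a limit. On that basis compound 3 is expected to give about 40000 nM in this assay, between 15000 nM and 120000 nM, an expected step of a 3.1-fold higher number from compound 2 to compound 3 (0.49 log units; beyond the scatter), with a fair chance that only a limit is reported.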

Compound 3, half-maximal inhibitory concentration: 25700 nM
Beside the measured number, compound 3's estimate is 1.6-fold (0.19 log units) above it, and the stated range covers the measured number.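

The step of a 2.0-fold higher number from compound 2 to compound 3 (0.30 log units; within the scatter) shows that, in this assay, 2,3-difluorophenyl and 4-methylphenyl on this oxygen cannot be told apart, so the methyl group of compound 2 is not needed to keep a measurable result. Fluorine on this ring does not by itself rule out a measured number: compound 3 carries two fluorines and gives 25700 nM, while the step of an at least 1.9-fold lower number from compound 1 to compound 3 (0.28 log units; that floor lies within the scatter) offers only a floor. Compound 1 stands at a limit and not a number, so that step cannot rank the two fluorinated rings: the limit of > 50000 nM in this assay, at which 1 of the 3 values shown sits.

On these data alone, whether a methoxy group or an amine on the phenyl ring, or a longer chain in place of that ring, would move the number beyond the scatter stays open. Also open is how each of the two fluorines contributes on its own, since the compounds shown do not separate them.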